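A few compounds are considered here, and "the series" means these few. Any claim that something is new, unique, unknown or untested is made for them only; others in the source may bear on it.

Measured so far:
compound 1 `O=C(/C=C/c1ccc(Br)cc1)Oc1ccc(/C=C2\CCCCC2=O)cc1` — > 50000 nM
compound 2 `O=C(/C=C/c1ccc(Cl)c(Cl)c1)Oc1ccc(/C=C2\CCCCC2=O)cc1` — > 50000 nM
compound 3 `CN(C)CC1CCC/C(=C\c2ccc(OC(=O)/C=C/c3ccc(Br)cc3)cc2)C1=O` — 4030 nM

All three have been tested in a functional assay on P388 cells (Mus musculus); on this read-out higher numbers stand for weaker inhibition and lower numbers for stronger inhibition. For compound 1 the value > 50000 nM is a limit of the assay, not a number. For compound 2 the value > 50000 nM is likewise a limit. Only compound 3 gives a number in this assay, namely 4030 nM. The cores of compound 1 and compound 3 differ by (dimethylamino)methyl in place of hydrogen on a saturated ring carbon, and this brings an at least 12-fold lower number from compound 1 to compound 3 (1.09 log units; beyond the scatter). The change 3,4-dichlorophenyl in place of 4-bromophenyl on a double-bonded chain carbon bound to a double-bonded chain carbon gives a step that the two limits leave unreadable from compound 1 to compound 2, since both values sit at the limit of > 50000 nM in this assay, at which 2 of the 3 values shown sit.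

Compound 4 `CN(C)CC1CCC/C(=C\c2ccc(OC(=O)/C=C/c3ccc(Cl)c(Cl)c3)cc2)C1=O` has not yet been measured. Going by the values given here, it differs from compound 3 by 3,4-dichlorophenyl in place of 4-bromophenyl on a double-bonded chain carbon bound to a double-bonded chain carbon, the same change as the one made between compound 1 and compound 2, at the same place. That earlier step left no readable size, so the expectation for compound 4 rests on compound 3 and its value 4030 nM alone. The step from compound 3 is expected to be a 1.0-fold lower number from compound 3 to compound 4 (0.00 log units; within the scatter), a small one. Compound 4 is therefore estimated at 4000 nM in this assay.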

Compound 4, half-maximal inhibitory concentration: 4180 nM
Compound 4: the middle estimate sits 1.0-fold (0.02 log units) below what was measured; the measured number falls inside the stated range.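

In this assay, 3,4-dichlorophenyl in place of 4-bromophenyl gives a 1.0-fold higher number from compound 3 to compound 4 (0.02 log units; within the scatter), so on the core carrying (dimethylamino)methyl the swap shows no readable change, while the same swap on the core without that group cannot be read. Adding (dimethylamino)methyl on a saturated ring carbon gives an at least 11-fold lower number from compound 2 to compound 4 (1.07 log units; beyond the scatter), so this change brings a large drop in the number with either aromatic group: the same change on two cores in this assay, an at least 12-fold lower number (1.09 log units; beyond the scatter) from compound 1 to compound 3 and an at least 11-fold lower number (1.07 log units; beyond the scatter) from compound 2 to compound 4; the limit leaves it open whether they differ. This shows that the drop carries over to a second core, but not how large it truly is on either one, because compound 1 and compound 2 each give a limit and not a number: the limit of > 50000 nM in this assay, at which 2 of the 4 values shown sit.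

The compounds shown leave open whether a plain methyl in place of (dimethylamino)methyl would also lower the number, and so whether the amine itself is needed. Also open, from the compounds shown here alone, is whether a larger amine such as piperidine would do as well as the dimethylamino group.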